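A few compounds are considered here, and "the series" means these few. Any claim that something is new, unique, unknown or untested is made for them only; others in the source may bear on it.

Compound 1, `CC(C)c1nc(C(=O)NC[C@@H]2[C@H]3CN(C4CCC4)C[C@@H]23)c2ccccn12`: 59%
Compound 2, `CC(C)c1nc(C(=O)NC[C@@H]2[C@H]3CN(C4CCOCC4)C[C@@H]23)c2ccccn12`: 43%
Compound 3, `COC(=O)N1CCC(N2C[C@@H]3[C@@H](CNC(=O)c4nc(C(C)C)n5ccccc45)[C@@H]3C2)CC1`: 42%

Of the compounds shown here, three have been measured in a functional assay on CHO cells for agonist activity at 5-hydroxytryptamine receptor 4 (Homo sapiens), read by a luciferase reporter and cAMP accumulation, with a stated time of 4 h; a lower number here means a smaller maximal response, a higher number a larger maximal response. Compound 3 stands lowest of the three numbers; its nearest neighbour is compound 2, and the two lie within the scatter of each other, while compound 1 stands furthest from it, beyond the scatter.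

Compound 4, `CC(C)c1nc(C(=O)NC[C@@H]2[C@H]3CN(CC(C)(C)CO)C[C@@H]23)c2ccccn12`, has not yet been measured. It differs from compound 3 in one place: 2-(hydroxymethyl)-2-methylpropyl in place of 1-(methoxycarbonyl)piperidin-4-yl on an amine nitrogen in a ring. The measured steps that bear on this change are those at the same amine nitrogen in a ring. a number 17 percentage points lower from compound 1 to compound 3 (beyond the scatter) and a number 16 percentage points lower from compound 1 to compound 2 (beyond the scatter), whereas a number 1 percentage points lower from compound 2 to compound 3 (within the scatter). So swapping one ring-bearing group for another at this position left the number essentially where it was, while both ring-bearing groups gave a modest fall against the cyclobutyl of compound 1. Going by the values given here, no measured step involves a group without a ring at this position, so the direction of the coming step is uncertain, and a step within the scatter, or a small rise, seems most likely.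

Compound 4 is therefore expected to give 48%, with a range from 35% to 62%. The estimate for compound 4 amounts to an expected a number 6 percentage points higher from compound 3 to compound 4 (within the scatter).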

Compound 4, largest response reached (Emax), in percent of the reference or control that the assay uses: 40%
For compound 4 the middle estimate is 8 percentage points above the measured one; low and high end bracket the measured number.
By their numbers in this assay, from the lowest: compounds 4, 3 and 2 (each within the scatter of the next); then compound 1.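

In this assay, the measured steps for 2-(hydroxymethyl)-2-methylpropyl, a group with no ring, are a number 2 percentage points lower from compound 3 to compound 4 (within the scatter) and a number 3 percentage points lower from compound 2 to compound 4 (within the scatter), set against a number 19 percentage points lower from compound 1 to compound 4 (beyond the scatter). This shows that a ring in the group on this amine nitrogen is not needed for the lower level: the chain cannot be told apart from oxan-4-yl or 1-(methoxycarbonyl)piperidin-4-yl, although it has fewer heavy atoms than 1-(methoxycarbonyl)piperidin-4-yl and, unlike that group, carries a hydrogen-bond donor, so among these four compounds only the cyclobutyl of compound 1 stands apart. No measurement at hand gives a reason for this.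

The compounds shown leave open whether the larger response of compound 1 belongs to cyclobutyl alone, or would also come with cyclopropyl, cyclopentyl or a plain isobutyl chain. They also leave open what the hydroxyl at the end of the chain contributes, which a neopentyl group without it, or a chain ending in a carboxylic acid or an amine, would address.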